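Nitro for trifluoromethyl on a second macrocyclic core

The compounds below may be only part of what the source reports. "The series", "measured", "known", "first", "only" and "open" are said of these compounds alone.

Compound 1 `FC(F)(F)c1ccc(COc2cccc(Nc3ncnc4cc5c(cc34)OCCOCCOCCOCCO5)c2)cc1` and compound 2 `O=[N+]([O-])c1ccc(COc2cccc(Nc3ncnc4cc5c(cc34)OCCOCCOCCOCCO5)c2)cc1` share one core and differ only in the change (nitro in place of trifluoromethyl on an aromatic carbon). In a functional assay on SH-SY5Y cells (Homo sapiens) for antiproliferative activity, read by MTT assay, with a stated time of 72 h (a lower number here means a stronger inhibitor, a higher number a weaker inhibitor), compound 1 gives 8560 nM, and compound 2 gives 8420 nM; the step is a 1.0-fold lower number from compound 1 to compound 2 (0.01 log units; within the scatter), so the two numbers cannot be told apart.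

Compound 3 `FC(F)(F)c1ccc(COc2cccc(Nc3ncnc4cc5c(cc34)OCCOCCO5)c2)cc1` carries the same trifluoromethyl group on a different core; the difference between the two cores is not broken down here. In this assay, going by the values given here, compound 3 gives 19300 nM, the highest of the three numbers so far, and its distance from compound 1 lies beyond the scatter.

Compound 4 `O=[N+]([O-])c1ccc(COc2cccc(Nc3ncnc4cc5c(cc34)OCCOCCO5)c2)cc1` is not yet measured. It stands to compound 3 as compound 2 stands to compound 1: the change nitro in place of trifluoromethyl on an aromatic carbon is the same change, made at the same place. Because the earlier step was a 1.0-fold lower number from compound 1 to compound 2 (0.01 log units; within the scatter), the step is expected to be a 1.0-fold lower number from compound 3 to compound 4 (0.01 log units; within the scatter), essentially flat. Compound 4 is therefore estimated at 19000 nM in this assay, expected to fall between 9000 nM and 40000 nM.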

Compound 4, half-maximal inhibitory concentration: 36600 nM
The estimate for compound 4 lay 1.9-fold (0.28 log units) below the measured number, and the stated range covers the measured number.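

In this assay, the step for nitro in place of trifluoromethyl on the second core is a 1.9-fold higher number from compound 3 to compound 4 (0.28 log units; within the scatter), so on this core too the two compounds cannot be told apart. Set beside the earlier step, the change reads the same on both cores: the same change on two cores in this assay, a 1.0-fold lower number (0.01 log units; within the scatter) from compound 1 to compound 2 and a 1.9-fold higher number (0.28 log units; within the scatter) from compound 3 to compound 4, 1.9-fold (0.29 log units) apart, within the scatter of two such steps. For these two pairs, 4-(trifluoromethyl)benzyl and 4-nitrobenzyl thus carry from one core to the other with no difference that can be resolved, but this rests on two pairs in a single cell assay and does not show that the same would hold on another core or in another assay.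

The compounds shown carry only trifluoromethyl or nitro at this place, so it remains open how a nitrile, an amine or a chlorine atom there would compare on either core. On these data alone, it also remains open whether the two groups would still match on a core with a macrocyclic chain of another length.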